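Cyclopentyl to Cyclohexyl on the Amide Nitrogen

The source may hold more compounds than are shown below. What is called first, only, known or untested is meant among the compounds shown, and "the series" means these compounds.

Compound 1 `CC(C)=CCC/C(C)=C/CC/C(C)=C/CSC[C@H](NC(=O)CCCCCN1CCN(C)CC1)C(=O)NC1CCCCCC1`: 5.44
Compound 2 `CC(C)=CCC/C(C)=C/CC/C(C)=C/CSC[C@H](NC(=O)CCCCCN1CCN(C)CC1)C(=O)NC1CCCC1`: 4.55

In a physicochemical assay for lipophilicity (on this read-out lower numbers stand for lower lipophilicity and higher numbers for higher lipophilicity), compound 1 gives 5.44, and compound 2 gives 4.55. Compound 2 stands lowest of the two measured compounds, separated by a number 0.89 log units lower from compound 1 to compound 2 (beyond the scatter). Compound 3 `CC(C)=CCC/C(C)=C/CC/C(C)=C/CSC[C@H](NC(=O)CCCCCN1CCN(C)CC1)C(=O)NC1CCCCC1` differs from compound 2 by cyclohexyl in place of cyclopentyl on an amide-type nitrogen. Among the compounds with values here, the only measured step that bears on this is a number 0.89 log units lower from compound 1 to compound 2 (beyond the scatter), the same kind of ring-size change, larger and in the opposite direction. A rise smaller than that step is therefore expected. Compound 3 is estimated at 5, between 4.7 and 5.3, an expected step of a number 0.45 log units higher from compound 2 to compound 3 (beyond the scatter).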

Compound 3, distribution coefficient: 4.99
Beside the measured number, compound 3's estimate is 0.01 log units above it, within the range that was stated.
By their numbers in this assay, from the lowest: compound 2; then compound 3; then compound 1.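

In this assay, the cyclohexyl group on the amide-type nitrogen falls midway between the other two rings: the change from cyclopentyl gives a number 0.44 log units higher from compound 2 to compound 3 (beyond the scatter), and the change from cycloheptyl gives a number 0.45 log units lower from compound 1 to compound 3 (beyond the scatter). Across these three compounds, the number therefore climbs in near-even steps as the ring grows, with none going against this order. Nothing measured here explains that spacing. Going by these compounds, whether the order extends to a smaller ring such as cyclobutyl, or holds for an open chain such as hexyl or a ring containing nitrogen such as piperidinyl, remains open.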